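The source may report more compounds than this note shows. Statements on the series, on what has been measured and on what is new or still open speak of the compounds shown alone.

The measured compounds are compound 1 `CNC(=O)/C=C/c1ccncc1-c1ccc2ccccc2c1`, compound 2 `CCOC(=O)/C=C/c1ccncc1-c1ccc2c(cnn2C)c1` and compound 3 `CCOC(=O)/C=C/c1ccncc1-c1ccc2[nH]ccc2c1`.

In an assay on a protein complex for inhibition of CDK8/Cyclin C (Homo sapiens), with a stated time of 1 h (a lower number here means a stronger inhibitor, a higher number a weaker inhibitor), compound 1 gives 12.4 nM. Compound 2 gives 102 nM. Compound 3 gives 107 nM. Going by the values given here, compound 1 thus stands lowest of the three numbers, with compound 2 and compound 3 both beyond the scatter above it; each of those differs from compound 1 in more than one place, and no single step joins them. Compound 4 `CCOC(=O)/C=C/c1ccncc1-c1ccc2ccccc2c1` differs from compound 1 in one place only: ethoxy in place of methylamino on a carbonyl carbon. Compound 2 and compound 3, which carry the same ethoxycarbonyl group, give the higher numbers in this assay. For compound 4 an upward step beyond the scatter is expected, a 3.2-fold higher number from compound 1 to compound 4 (0.51 log units; beyond the scatter). Compound 4 is estimated at 40 nM, within a range of 12 nM to 130 nM.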

Compound 4, half-maximal inhibitory concentration: 53.3 nM
Estimate against measurement, compound 4: 1.3-fold (0.12 log units) below; low and high end bracket the measured number.
By their numbers in this assay, from the lowest: compound 1; then compounds 4, 2 and 3 (each within the scatter of the next).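

In this assay, ethoxy in place of methylamino on a carbonyl carbon gives a 4.3-fold higher number from compound 1 to compound 4 (0.63 log units; beyond the scatter) and so shows, on a single shared core, that this position responds to the change. Compound 2 and compound 3 could not show this, since no single change joined them to compound 1. Nothing measured here gives a reason for the step.

On these data alone, what a carboxylic acid, a primary amide or a dimethylamide would give on this carbonyl carbon remains open. Also open, as far as these compounds go, is whether the step holds on the cores of compound 2 and compound 3.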